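Alkyne to Alkene on the Aryl Side Chain

A few compounds are considered here, and "the series" means these few. Any claim that something is new, unique, unknown or untested is made for them only; others in the source may bear on it.

Measured so far:
- compound 1 `CCN(CC)CCNC(=O)C1CC=C(C(CC)(CC)c2ccc(C#CC(C)(O)CC)c(C)c2)N1CC`: 63.4%
- compound 2 `CCN(CC)CCNC(=O)C1CC(C(CC)(CC)c2ccc(CCC(O)(CC)CC)c(C)c2)=CN1CC`: 35.9%

Of the compounds shown here, two have been tested in an assay on isolated protein for binding affinity to vitamin D3 receptor (Homo sapiens), read by fluorescence polarization, tested at 1 uM; on this read-out higher numbers stand for more inhibition at the one concentration tested (going by the name of the read-out) and lower numbers for less inhibition. Compound 1 gives 63.4%, the higher of the two numbers. Compound 2 gives 35.9%, which lies lower by a gap beyond the usual scatter. Going by the values given here, the two compounds differ in more than one place, so no single-change step between measured compounds is available to guide an expectation.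

The next compound, compound 3 `CCN(CC)CCNC(=O)C1CC=C(C(CC)(CC)c2ccc(/C=C/C(C)(O)CC)c(C)c2)N1CC`, has not yet been measured in this assay. Relative to compound 1 the change is a group of 7 heavy atoms (6 carbon, 1 oxygen; no ring) in place of a group of 7 heavy atoms (6 carbon, 1 oxygen; no ring), on an aromatic carbon; the group that leaves carries a triple bond outside aromatic rings, the group that enters a double bond, while the count of heavy atoms, donors and acceptors stays the same.

Among the compounds with values here, with no measured step of this kind, the step is expected to be small, possibly a slight decrease, and compound 3 is estimated at 55%, within 35% to 75%, so that the expected step is a number 8.4 percentage points lower from compound 1 to compound 3 (within the scatter).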

Compound 3, a percentage reported as inhibition, at one concentration (the size of the read-out at that concentration, not a potency): 68.9%
Compound 3: the middle estimate sits 13.9 percentage points below what was measured, within the range that was stated.
By their numbers in this assay, from the lowest: compound 2; then compounds 1 and 3 (each within the scatter of the next).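

In this assay, going by these compounds alone, putting a double bond in place of the triple bond in the side chain gives a number 5.5 percentage points higher from compound 1 to compound 3 (within the scatter), the first single-change step in this set, and it lies within the scatter. At this position, on an aromatic carbon ortho to a methyl group and para to a large group, the triple-bond and double-bond side chains therefore cannot be told apart on the core of compound 1, at least at the one concentration tested, where the read-out is not a potency. No independent information bears on why the two compounds read alike.

The compounds shown leave open what a fully saturated link would do on the core of compound 1, since compound 2 carries such a link but differs from compound 1 in more than one place and so gives no clean comparison. They also leave open whether the hydroxyl group on this side chain can give way to an amine or a carboxylic acid, and whether a longer chain at the same carbon would keep the read-out where compound 1 and compound 3 stand.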